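Formyl to hydroxymethyl: a step behind an assay limit

This account rests on a few compounds, and the source may have more. Where it says the series, first, only, none or still open, it means among the compounds named here.

compound 1 `C=C[C@@](C)(/C=C/c1ccc(O)cc1)CC/C=C/C#N`: > 52000 nM
compound 2 `C=C[C@@](C)(/C=C/c1ccc(O)cc1)CC/C=C(C)/C=N/N`: > 52000 nM
compound 3 `C=C[C@@](C)(/C=C/c1ccc(O)cc1)CC/C=C(\C)C=O`: > 52000 nM

All three compounds were tested in a functional assay on HepG2 cells (Homo sapiens) for cytotoxicity, with a stated time of 72 h (a higher number here means that more compound is needed for the effect, a lower number that less compound is needed), and each entry above is a limit, not a number. Compound 3 gives > 52000 nM, which is a limit. It therefore stands at the limit of > 52000 nM in this assay, at which 3 of the 3 values shown sit.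

Compound 4 `C=C[C@@](C)(/C=C/c1ccc(O)cc1)CC/C=C(\C)CO` carries hydroxymethyl in place of formyl on a double-bonded chain carbon bound to a double-bonded chain carbon and a saturated chain carbon.

Two measured changes bear on this one. The closest is a step that the two limits leave unreadable from compound 2 to compound 3, and the other is a step that the two limits leave unreadable from compound 1 to compound 3. Neither has a size that can be read, so they offer no direction for the new change. Compound 4 is therefore expected to show no step beyond the scatter in this assay, and most likely to reach the same limit. The expected step is a step that the limit leaves unreadable from compound 3 to compound 4. For compound 4 the estimate is 60000 nM, with an expected range of 25000 nM to 120000 nM.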

Compound 4, half-maximal effective concentration: > 52000 nM
Compound 4 gave a limit, no number; the forecaster's own chance of this, stated with the estimate: 85%; the middle value does not contradict the limit.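

In this assay compound 4 gives > 52000 nM, which is a limit. No step from compound 1, compound 2 or compound 3 to compound 4 can be read, because all four compounds share one limit: the limit of > 52000 nM in this assay, at which 4 of the 4 values shown sit.

The compounds shown leave open whether hydroxymethyl in place of formyl changes the concentration needed for the effect.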